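Pyridin-4-yl in place of 3-methoxyphenyl in compound 1

The compounds below may be only part of what the source reports. "The series", "measured", "known", "first", "only" and "open" are said of these compounds alone.

Among the measured compounds shown here, in a physicochemical assay for lipophilicity, at pH 7.4 (a higher number here means a more lipophilic compound, a lower number a more polar compound), compound 1 `CNC(=O)c1cc(C(=O)N[C@H]2[C@@H]3COC[C@@H]32)cc2c1OC[C@H]2c1cccc(OC)c1` gives 3.2, the lowest of the three numbers measured so far. Compound 3 `CNC(=O)c1cc(C(=O)N[C@H]2[C@@H]3C[C@H](O)C[C@@H]32)cc2c1OC[C@@]2(C)c1ccccc1` gives 3.7, and compound 2 `CNC(=O)c1cc(C(=O)NC2CC2)cc2c1OC[C@H]2c1cccc(OC)c1` gives 3.8, so both stand higher than compound 1 by more than the scatter.

Compound 4 `CNC(=O)c1cc(C(=O)N[C@H]2[C@@H]3COC[C@@H]32)cc2c1OC[C@H]2c1ccncc1` has not yet been measured. It differs from compound 1 in one place: pyridin-4-yl in place of 3-methoxyphenyl on a saturated ring carbon. Pyridin-4-yl thus takes the place of 3-methoxyphenyl on a saturated ring carbon, while the rest of the structure stays the same.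

For the measured compounds named here, only one measured step connects compounds that differ in a single place: a number 0.60 log units higher from compound 1 to compound 2 (beyond the scatter). That change sits on an amide-type nitrogen, not on the saturated ring carbon, so it bears on compound 4 only indirectly. It shows that one change in this series can move the number beyond the scatter, but it says nothing about this exchange of rings. The direction and size therefore rest on the structural change alone and remain a judgement.

A fall larger than the measured step is expected in this assay, and the estimated change is a number 1.10 log units lower from compound 1 to compound 4 (beyond the scatter). The expected value for compound 4 is 2.1, with an estimated range from 1.6 to 2.6.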

Compound 4, distribution coefficient: 1.3
Beside the measured number, compound 4's estimate is 0.80 log units above it, outside the stated range (below it).
By their numbers in this assay, from the lowest: compound 4; then compound 1; then compounds 3 and 2 (each within the scatter of the next).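

On the saturated ring carbon, two ring bonds from the ring oxygen, the exchange of one six-membered aromatic ring for another gives the largest move seen so far in this assay: a number 1.90 log units lower from compound 1 to compound 4 (beyond the scatter). Among the compounds shown here, the only earlier step, a number 0.60 log units higher from compound 1 to compound 2 (beyond the scatter), lay on an amide-type nitrogen, ran the other way and was smaller, so this position can move the number at least as far as that amide substituent can. The counts of hydrogen-bond donors and acceptors and the net charge are the same for 3-methoxyphenyl and pyridin-4-yl, so they do not distinguish the two groups, and no measurement given here accounts for the fall.

The exchange brings in a ring nitrogen and removes the methoxy group in a single step, and the compounds shown cannot separate these two parts; pyridin-3-yl or a pyridine ring carrying a methoxy group on this carbon would bear on that question. On these data alone, it also stays open whether pyridin-4-yl would give a step of similar size with the cyclopropyl amide of compound 2.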